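Phenyl for methylpyrazolyl on the amide nitrogen

The source may hold more compounds than are shown below. What is called first, only, known or untested is meant among the compounds shown, and "the series" means these compounds.

Compound 1 `Cc1ccc(OCC(=O)N(Cc2cccs2)c2ccnn2C)cc1`: 422 nM
Compound 2 `CCN(Cc1cccs1)C(=O)COc1cccc(C)c1`: 97 nM

In an assay on HEK293 cells for agonist activity at transient receptor potential cation channel subfamily M member 8 (Homo sapiens), read by fluorescence and calcium flux, with a stated time of 15 min (a higher number here means that more compound is needed for the effect, a lower number that less compound is needed), compound 1 gives 422 nM, the higher of the two numbers measured. In this assay compound 2 gives 97 nM, a lower number that lies beyond the usual scatter. Compound 3 `Cc1ccc(OCC(=O)N(Cc2cccs2)c2ccccc2)cc1` has not yet been measured. It differs from compound 1 by phenyl in place of 1-methyl-1H-pyrazol-5-yl on an amide-type nitrogen. Among the compounds with values here, no measured pair shows this change, so the step from compound 1 to compound 3 is uncertain. A modest step toward a lower number is expected, possibly within the scatter, as a 1.7-fold lower number from compound 1 to compound 3 (0.23 log units; within the scatter). For compound 3 the estimate is 250 nM, with a range from 60 nM to 1000 nM.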

Compound 3, half-maximal effective concentration: 23 nM
For compound 3 the middle estimate is 11-fold (1.04 log units) above the measured one; the measured number lies below the stated range.
By their numbers in this assay, from the lowest: compound 3; then compound 2; then compound 1.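

In this assay the group on the amide-type nitrogen matters strongly: phenyl in place of 1-methyl-1H-pyrazol-5-yl gives an 18-fold lower number from compound 1 to compound 3 (1.26 log units; beyond the scatter) and this is a large step. The two rings have the same number of heavy atoms, so the change in the number lies with the exchange of one aromatic ring for the other and not with the heavy-atom count. Nothing available explains the size of this step. The compounds shown leave open how a pyridyl or cyclohexyl group on this nitrogen would read, and whether a fluorine or methoxy group on the phenyl ring would move the number further.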